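Swapping a Sulfonyl Group for Ethoxy on a Bcl-2 Binder

The compounds below may be only part of what the source reports. "The series", "measured", "known", "first", "only" and "open" are said of these compounds alone.

Of the compounds shown here, three have been tested in an assay for binding affinity to Apoptosis regulator Bcl-2 (Homo sapiens), read by fluorescence polarization, with a stated time of 2 h; a lower number here means a stronger inhibitor, a higher number a weaker inhibitor. Compound 1 `Cc1c(C(=O)O)c(-c2cccc(N3CCN(c4ccc(NS(=O)(=O)c5ccc(N[C@H](CCN6CCC(O)CC6)CSc6ccccc6)c(S(=O)(=O)C(F)(F)F)c5)cc4)CC3)c2)c(-c2ccc(Cl)cc2)n1C` gives 2.4 nM, and compound 3 `CCn1c(C)c(C(=O)O)c(-c2cccc(N3CCN(c4ccc(NS(=O)(=O)c5ccc(N[C@H](CCN6CCC(O)CC6)CSc6ccccc6)c(S(=O)(=O)C(F)(F)F)c5)cc4)CC3)c2)c1-c1ccc(Cl)cc1` gives 1.2 nM. Compound 2 `Cc1c(C(=O)NCCCN2CCN(C)CC2)c(-c2cccc(N3CCN(c4ccc(NS(=O)(=O)c5cccc(S(=O)(=O)C6CC6)c5)cc4)CC3)c2)c(-c2ccc(Cl)cc2)n1C` gives 218 nM, the highest number of the three and well beyond the scatter from both others, so it stands as the weakest binder measured.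

Compound 4 `CCOc1cccc(S(=O)(=O)Nc2ccc(N3CCN(c4cccc(-c5c(C(=O)NCCCN6CCN(C)CC6)c(C)n(C)c5-c5ccc(Cl)cc5)c4)CC3)cc2)c1` is compound 2 with one change: ethoxy in place of cyclopropylsulfonyl on an aromatic carbon. Going by the values given here, no measured pair shows this kind of exchange, so the expectation rests on compound 2 alone. A modest shift toward a weaker result is expected, as step a 2.3-fold higher number from compound 2 to compound 4 (0.36 log units; beyond the scatter) in this assay, though a result within the scatter would not be surprising. For compound 4 the estimate is 500 nM, with a range from 150 nM to 2000 nM.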

Compound 4, inhibition constant: 420 nM
Beside the measured number, compound 4's estimate is 1.2-fold (0.08 log units) above it, within the range that was stated.
By their numbers in this assay, from the lowest: compounds 3 and 1 (each within the scatter of the next); then compounds 2 and 4 (each within the scatter of the next).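

In this assay, going by these compounds alone, the exchange gives a 1.9-fold higher number from compound 2 to compound 4 (0.28 log units; within the scatter), the first direct reading of a change at this position. On this aromatic carbon, then, cyclopropylsulfonyl can give way to the smaller ethoxy, with no ring and one hydrogen-bond acceptor fewer, without a difference that stands clear of the scatter. Nothing shown explains why the two groups read alike. The compounds shown leave open how an amine or a longer alkoxy chain would read on this carbon. They also leave open whether this exchange would read the same on another core.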